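Working notes: acetamido in place of nitro

The source may hold more compounds than are shown below. What is called first, only, known or untested is meant among the compounds shown, and "the series" means these compounds.

compound 1 `Oc1ccc(-c2nc3cc(C(F)(F)F)ccc3[nH]2)cc1` gives 17000 nM
compound 2 `O=[N+]([O-])c1ccc(-c2nc3cc(Cl)c(Cl)cc3[nH]2)cc1` gives 17000 nM

In an ADME assay on MT4 cells (Homo sapiens) for cytotoxicity, read by MTT assay, with a stated time of 96 h (a lower number here means that less compound is tolerated, a higher number that more compound is tolerated), compound 2 gives 17000 nM and so stands level with compound 1, the two lying within the scatter. Within the data shown here, no step between measured compounds that differ in one place is available, so nothing in this small set sizes the next change directly. Compound 3 `CC(=O)Nc1ccc(-c2nc3cc(Cl)c(Cl)cc3[nH]2)cc1` keeps the rest of compound 2, and the change acetamido in place of nitro on an aromatic carbon puts acetamido in place of nitro on an aromatic carbon, para to a large group. In this assay a small move towards more compound tolerated is expected, and it may well stay within the scatter. The estimated change is a 1.5-fold higher number from compound 2 to compound 3 (0.17 log units; within the scatter) for this single swap. For compound 3 the expected value is 25000 nM with an estimated range of 8000 nM to 80000 nM for the coming measurement.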

Compound 3, half-maximal cytotoxic concentration: > 100000 nM
Compound 3 gave a limit, no number; the forecaster's own chance of this, stated with the estimate: 25%; middle value at least 4.0-fold (0.60 log units) away from the limit.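

In this assay, among these compounds, acetamido in place of nitro on an aromatic carbon, para to a large group, gives an at least 5.8-fold higher number from compound 2 to compound 3 (0.76 log units; beyond the scatter), the first single-place step and one that lies beyond the scatter. Compound 3 reads > 100000 nM, which is a limit of the assay and not a number. This position can therefore move the read-out, but the full size of the step stays unread: the limit of > 100000 nM in this assay, at which 1 of the 3 values shown sits.

On these data alone, whether the step belongs to the arrival of acetamido or to the departure of nitro remains open, and an amine or a carboxylic acid on the same carbon would help separate the two. Also open, as far as these compounds go, is whether the same swap gives a step of similar size on a core carrying other ring substituents, since compound 1 differs from compound 2 in more than one place.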